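Ester Chain Length and Metabolic Stability in a Carbamate Series

This account rests on a few compounds, and the source may have more. Where it says the series, first, only, none or still open, it means among the compounds named here.

Measured compounds:
compound 1, `CCCCNC(=O)Oc1ccc(Cl)cc1C(=O)Nc1cccc(Cl)c1`, 64 h
compound 2, `CCCCCCNC(=O)Oc1ccc(Cl)cc1C(=O)Nc1cccc(Cl)c1`, 64 h
compound 3, `CCCNC(=O)Oc1ccc(Cl)cc1C(=O)Nc1ccc(Cl)cc1`, 64 h

In an ADME assay for metabolic stability, read by HPLC, at pH 7 (on this read-out higher numbers stand for a longer-lived compound and lower numbers for a shorter-lived compound), compound 1 gives 64 h and compound 2 gives 64 h. The step between them, (ethyl in place of hydrogen on a saturated chain carbon, four bonds along the chain from an amide-type nitrogen), is no change at the digits printed from compound 1 to compound 2 (within the scatter). Compound 3, built on a different core, gives 64 h in this assay; the difference between the two cores is not broken down here. Compound 4, `CCCCCNC(=O)Oc1ccc(Cl)cc1C(=O)Nc1ccc(Cl)cc1`, is not yet measured. Going by the values given here, it differs from compound 3 by ethyl in place of hydrogen on a saturated chain carbon, three bonds along the chain from an amide-type nitrogen, the same kind of change as the one from compound 1 to compound 2, though there the ethyl enters four bonds along the chain from the amide-type nitrogen, here three. Since compound 3 sits level with compounds 1 and 2, the step from compound 3 to compound 4 is expected to be no change at the digits printed from compound 3 to compound 4 (within the scatter). Compound 4 is estimated at 64 h, between 35 h and 120 h.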

Compound 4, half-life: 64 h
Compound 4: middle estimate and measured number agree at the digits printed; the measured number falls inside the stated range.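

In this assay, ethyl in place of hydrogen on a saturated chain carbon, three bonds along the chain from an amide-type nitrogen, gives no change at the digits printed from compound 3 to compound 4 (within the scatter). Set beside the same kind of change on the other core, where the ethyl enters four bonds along the chain, the result carries over in this one pair: the same change on two cores in this assay, no change at the digits printed (within the scatter) from compound 1 to compound 2 and no change at the digits printed (within the scatter) from compound 3 to compound 4, 1.0-fold (0.00 log units) apart, within the scatter of two such steps. This shows that the change left the read-out level on both cores, but it does not show that the change would carry over to a third core, or that it would do so at other places on the chain.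

What the compounds shown leave open is whether a longer chain, or an amine or a carboxylic acid in place of the ethyl, would shift the half-life on either core.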